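Amide variation in this series: compound 1 to compound 4

The source may report more compounds than this note shows. Statements on the series, on what has been measured and on what is new or still open speak of the compounds shown alone.

Compound 1 `COc1ccc(/C=C/c2cc(OC)cc(OC)c2/C=C/C(=O)N2CCCCC2C)cc1` is characterised in a functional assay on A549 cells (Homo sapiens) for inhibition, read by MTT assay, with a stated time of 48 h (on this read-out higher numbers stand for weaker inhibition and lower numbers for stronger inhibition), where compound 1 gives 5770 nM. Among the three numbers in hand this is the second highest. Compound 2 `C#CCNC(=O)/C=C/c1c(/C=C/c2ccc(OC)cc2)cc(OC)cc1OC` gives 6930 nM, and the step of a 1.2-fold higher number from compound 1 to compound 2 (0.08 log units; within the scatter) is within the scatter. Compound 3 `COc1ccc(/C=C/c2cc(OC)cc(OC)c2/C=C/C(=O)N2CCC(Cl)CC2)cc1` gives 2080 nM, and the step of a 2.8-fold lower number from compound 1 to compound 3 (0.44 log units; beyond the scatter) is beyond the scatter, as is the step of a 3.3-fold lower number from compound 2 to compound 3 (0.52 log units; beyond the scatter).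

Compound 4 `COc1ccc(/C=C/c2cc(OC)cc(OC)c2/C=C/C(=O)N2CCCC(C)C2)cc1` differs from compound 1 in one place: 3-methylpiperidin-1-yl in place of 2-methylpiperidin-1-yl on a carbonyl carbon. The two measured steps both exchange the entire group on the carbonyl carbon; neither moves a methyl group within the same six-membered ring, so none bears directly on this change. The closest guide is that replacing 2-methylpiperidin-1-yl by propargylamino left the number within the scatter, and only 4-chloropiperidin-1-yl produced a modest step. A change that keeps the ring and its size and merely relocates the methyl group is therefore expected to give no step beyond the scatter, in either direction.

For compound 4 the estimate in this assay is 5200 nM, with a range from 2600 nM to 10500 nM. The expected step is a 1.1-fold lower number from compound 1 to compound 4 (0.05 log units; within the scatter), which lies within the scatter.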

Compound 4, half-maximal inhibitory concentration: 5820 nM
Estimate against measurement, compound 4: 1.1-fold (0.05 log units) below; low and high end bracket the measured number.
By their numbers in this assay, from the lowest: compound 3; then compounds 1, 4 and 2 (each within the scatter of the next).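

In this assay, among these compounds, relocating the methyl group is the first change at this position that keeps the ring and its size, and it gives a 1.0-fold higher number from compound 1 to compound 4 (0.00 log units; within the scatter), so 2-methylpiperidin-1-yl and 3-methylpiperidin-1-yl cannot be told apart on this read-out. Among the compounds shown here, the new group also cannot be told apart from propargylamino on the same carbonyl carbon, with a 1.2-fold lower number from compound 2 to compound 4 (0.08 log units; within the scatter), whereas a 2.8-fold higher number from compound 3 to compound 4 (0.45 log units; beyond the scatter) shows that 4-chloropiperidin-1-yl is set apart from this group as well, which makes it the only group of the four that stands apart from the rest. No measurement at hand accounts for either result.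

Going by these compounds, whether the separation of compound 3 goes with the chlorine or with the 4-substituted piperidine remains open, and 4-methylpiperidin-1-yl and 3-chloropiperidin-1-yl on the same carbonyl carbon would separate those two readings. The compounds shown also leave open how unsubstituted piperidin-1-yl or morpholin-4-yl would compare with the methylpiperidines in this series.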